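From methoxycarbonyl to ethoxycarbonyl at the assay limit

The source may report more compounds than this note shows. Statements on the series, on what has been measured and on what is new or still open speak of the compounds shown alone.

Compound 1 `CC(=O)N(C)C(C)C#CCn1ccnc1` gives > 100 mg/kg
Compound 2 `COC(=O)N(C)C(C)C#CCn1ccnc1` gives > 100 mg/kg
Compound 3 `COC(=O)N(C)C(C)C#CCn1cncc1C` gives > 100 mg/kg

In a functional assay on the whole organism for antagonist activity, with Mus musculus as the target (a higher number here means that more compound is needed for the effect, a lower number that less compound is needed), compound 3 gives > 100 mg/kg as a limit and not a number. Compound 3 thus stands at the limit of > 100 mg/kg in this assay, at which 3 of the 3 values shown sit, with no number to build on. Compound 4 `CCOC(=O)N(C)C(C)C#CCn1cncc1C` differs by one change (methyl in place of hydrogen on a saturated chain carbon bound to an oxygen next to a carbonyl group) that turns methoxycarbonyl into ethoxycarbonyl. The change on the carbonyl carbon gave a step that the two limits leave unreadable from compound 1 to compound 2 and the change on an aromatic carbon gave a step that the two limits leave unreadable from compound 2 to compound 3 so neither sets a size. A step beyond the scatter is therefore not expected in this assay and no direction can be read. The estimated value for compound 4 is 130 mg/kg with an expected range from 50 mg/kg to 300 mg/kg and another limit is quite likely.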

Compound 4, dose for half-maximal effect: 30 mg/kg
Compound 4: the middle estimate sits 4.3-fold (0.64 log units) above what was measured; the whole stated range lies above it.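

In this assay, adding one methyl to the methoxycarbonyl group to give ethoxycarbonyl produces an at least 3.3-fold lower number from compound 3 to compound 4 (0.52 log units; beyond the scatter). Within the data shown here, this shows that a single added carbon at this end of the molecule can lower the dose needed, something the earlier steps could not reveal. Compound 4 is the only compound here with a number rather than a limit: the limit of > 100 mg/kg in this assay, at which 3 of the 4 values shown sit.

From the compounds shown here alone, it remains open whether a longer chain, such as propyl or butyl, in place of ethyl would lower the dose further or raise it again. Going by these compounds, it is also open whether ethoxycarbonyl would have a similar effect without the methyl on the aromatic carbon.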